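Swapping an aryl group for a short branched chain

The source may hold more compounds than are shown below. What is called first, only, known or untested is meant among the compounds shown, and "the series" means these compounds.

Of the compounds shown here, three sharing one core have been measured in a physicochemical assay for solubility, with a stated time of 18 h, at pH 7.4; on this read-out lower numbers stand for lower solubility and higher numbers for higher solubility. Compound 1 `Fc1ccc(Cc2ccc3c(NCCCNCc4ccco4)ccnc3c2)c(Cl)c1` gives 4200 nM. Compound 2 `COc1ccc(-c2ccc3c(NCCCNCc4ccco4)ccnc3c2)cc1` gives 32000 nM, and compound 3 `FC(F)(F)c1ccc(-c2ccc3c(NCCCNCc4ccco4)ccnc3c2)cc1` gives 32000 nM. Compound 3 therefore stands level with compound 2, and the two together give the highest numbers of the three, while compound 1 is the furthest away, with a 7.6-fold higher number from compound 1 to compound 3 (0.88 log units; beyond the scatter) and likewise a 7.6-fold higher number from compound 1 to compound 2 (0.88 log units; beyond the scatter). Between compound 2 and compound 3 there is no change at the digits printed from compound 2 to compound 3 (within the scatter).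

The next compound, compound 4 `CCC(CC)c1ccc2c(NCCCNCc3ccco3)ccnc2c1`, differs from compound 3 in one place: pentan-3-yl in place of 4-(trifluoromethyl)phenyl on an aromatic carbon. Among the measured compounds shown here, none of the measured steps exchanges an aromatic group for a chain, so no step bears directly on this change. The two measured steps that leave compound 1 were modest, and the swap between compound 2 and compound 3 showed that changing the group on the outer ring left the number where it was. On that basis a step of no more than modest size is expected in this assay, with the direction uncertain, and a 1.3-fold higher number from compound 3 to compound 4 (0.10 log units; within the scatter) is the expected step. The estimate for compound 4 is 40000 nM, within a range from 12000 nM to 130000 nM.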

Compound 4, solubility: 4200 nM
The estimate for compound 4 lay 9.5-fold (0.98 log units) above the measured number; the whole stated range lies above it.
By their numbers in this assay, from the lowest: compounds 1 and 4 (each within the scatter of the next); then compounds 2 and 3 (each within the scatter of the next).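

In this assay the swap of methoxy for trifluoromethyl on the outer ring left the number where it was, yet replacing the whole aryl group with pentan-3-yl gives a 7.6-fold lower number from compound 3 to compound 4 (0.88 log units; beyond the scatter) and a 7.6-fold lower number from compound 2 to compound 4 (0.88 log units; beyond the scatter) on the same aromatic carbon, so this position is not indifferent to every change. The 2-chloro-4-fluorobenzyl group of compound 1 holds a ring and pentan-3-yl holds none, yet there is no change at the digits printed from compound 1 to compound 4 (within the scatter) between them, so the presence of a ring in the group does not by itself set the number. Across these four compounds, the two substituted phenyl groups, 4-methoxyphenyl and 4-(trifluoromethyl)phenyl, stand apart from the other two groups, and no compound shown goes against that split.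

Nothing shown here gives a reason for that split. As far as these compounds go, it also remains open whether a plain phenyl, a pyridine ring, a morpholine or a carboxylic acid on this aromatic carbon would sit with compounds 2 and 3 or with compounds 1 and 4.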